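The source may hold more compounds than are shown below. What is called first, only, known or untested is meant among the compounds shown, and "the series" means these compounds.

Compound 3 `COc1cc(Cl)cc(-c2nn(-c3cccc(NC(=O)Nc4ccc(Cl)c(C(F)(F)F)c4)c3)cc2-c2ccncc2)c1` stands, in a functional assay on SR cells (Homo sapiens) for inhibition, read by sulforhodamine B assay, with a stated time of 48 h, tested at 1 uM (a lower number here means a stronger effect, a higher number a weaker effect of the compound at the concentration tested), at 53%. That is the smallest of the three numbers at hand, yet its nearest neighbour, compound 1 `O=C(Nc1cccc(-n2cc(-c3ccncc3)c(-c3cc(O)cc(Cl)c3)n2)c1)Nc1ccc(Cl)c(C(F)(F)F)c1`, gives 57% in this assay, and compound 2 `O=C(Nc1cccc(-n2cc(-c3ccncc3)c(-c3cc(O)cc(Cl)c3)n2)c1)Nc1ccc(Cl)c(Cl)c1` gives 62%; both gaps are within the scatter, so the three compounds cannot be told apart on these readings. Compound 4 `COc1cc(Cl)cc(-c2nn(-c3cccc(NC(=O)Nc4ccc(Cl)c(Cl)c4)c3)cc2-c2ccncc2)c1` differs from compound 3 in one place: chloro in place of trifluoromethyl on an aromatic carbon. The same change has already been measured once on this scaffold, where a number 5 percentage points higher from compound 1 to compound 2 (within the scatter). The other measured step, a number 4 percentage points lower from compound 1 to compound 3 (within the scatter), alters a different site and does not bear directly on the present one. On that footing the step of a number 4 percentage points higher from compound 3 to compound 4 (within the scatter) is expected to remain within the scatter, with no real movement in either direction. Compound 4 is therefore estimated at 57%, with a likely range from 45% to 70%.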

Compound 4, a percentage reported as activity, at one concentration (the size of the read-out at that concentration, not a potency): 68%
Compound 4: the middle estimate sits 11 percentage points below what was measured; the range from low to high includes it.
By their numbers in this assay, from the lowest: compounds 3, 1, 2 and 4 (each within the scatter of the next, the first and the last beyond it).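

Within the data shown here, with methyl on the oxygen, chloro in place of trifluoromethyl gives a step beyond the scatter in this assay, a number 15 percentage points higher from compound 3 to compound 4 (beyond the scatter), the first reading at this position that stands clear of it. Even so, this step cannot be separated from the same change on the core with the free hydroxyl, so the core cannot be said to alter the effect of the change: the same change on two cores in this assay, a number 5 percentage points higher (within the scatter) from compound 1 to compound 2 and a number 15 percentage points higher (beyond the scatter) from compound 3 to compound 4, 10 percentage points apart, within the scatter of two such steps. Methyl on the oxygen still produces no readable movement, a number 6 percentage points higher from compound 2 to compound 4 (within the scatter), and this agrees with the earlier step at that site: the same change on two cores in this assay, a number 4 percentage points lower (within the scatter) from compound 1 to compound 3 and a number 6 percentage points higher (within the scatter) from compound 2 to compound 4, 10 percentage points apart, within the scatter of two such steps.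

The compounds shown leave open how a nitrile or an amine in place of trifluoromethyl would read at this position. They also leave open what a chain longer than methyl on the oxygen would do.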